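Chloroalkyl amides and an acylurea against M21 cells

A few compounds are considered here, and "the series" means these few. Any claim that something is new, unique, unknown or untested is made for them only; others in the source may bear on it.

Compound 1, `CC(C)(C)c1ccc(CNC(=O)NC(=O)CCl)cc1`, gives 2400 nM in a functional assay on M21 cells (Homo sapiens) for antiproliferative activity, with a stated time of 48 h; a lower number here means a stronger inhibitor, a higher number a weaker inhibitor.
Compound 2, `CC(C)(C)c1ccc(NC(=O)CCl)cc1`, gives 5400 nM in this assay.
Compound 3, `O=C(CCCl)Nc1ccc(I)cc1`, gives 20000 nM in this assay.

Among these three, compound 1 stands lowest in this assay; the gap to compound 2 is beyond the scatter, and the gap to compound 3 is larger still. Compound 4, `CC(C)(C)c1ccc(CNC(=O)CCCCl)cc1`, keeps the core of compound 1 and differs in one place: 3-chloropropyl in place of ((chloromethyl)carbonyl)amino on a carbonyl carbon. The acylurea of compound 1 thus gives way to a plain amide carrying a longer chloroalkyl chain. For the measured compounds named here, no measured pair shows this change directly, so its size is unknown. The only measured plain chloroalkyl amides, compound 2 and compound 3, both sit well above compound 1 in this assay, which suggests the step from compound 1 to compound 4 is expected to be a loss of potency beyond the scatter, as a 3.3-fold higher number from compound 1 to compound 4 (0.52 log units; beyond the scatter). Compound 4 is therefore estimated at 8000 nM in this assay, within a range from 2500 nM to 25000 nM.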

Compound 4, half-maximal inhibitory concentration: 69000 nM
The estimate for compound 4 lay 8.6-fold (0.94 log units) below the measured number; the measured number lies above the stated range.
By their numbers in this assay, from the lowest: compound 1; then compound 2; then compound 3; then compound 4.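

In this assay, putting 3-chloropropyl in place of ((chloromethyl)carbonyl)amino on a carbonyl carbon gives a 29-fold higher number from compound 1 to compound 4 (1.46 log units; beyond the scatter) and so is a large step, well beyond the scatter. For the compounds shown here, this is the first measured step at this position, and it shows that activity depends strongly on what sits there: the plain amide of compound 4 does not keep the level of the acylurea of compound 1. The data shown offer no measured explanation for the size of this step.

As far as these compounds go, the change alters the linker and the chloroalkyl chain together, so the share of each in the step remains open. A plain amide carrying chloromethyl on the core of compound 1, or an acylurea carrying 3-chloropropyl, would bear on that question.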